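A few compounds are considered here, and "the series" means these few. Any claim that something is new, unique, unknown or untested is made for them only; others in the source may bear on it.

In a functional assay on the whole organism (Hindlimb, strain albino) with Mus musculus as the target, in the maximal electroshock model, with a stated time of 0.5 h (on this read-out lower numbers stand for an effect already at smaller amounts and higher numbers for an effect only at larger amounts of compound), compound 2 (`O=C(/C=C/c1ccccc1)Nc1nc2ccc(Cl)cc2s1`) gives 425 umol/kg. Compound 1 (`Cc1ccc2nc(NC(=O)/C=C/OC3=CC=C3)sc2c1`) gives 505 umol/kg. These two numbers lie within the usual scatter of repeated measurements, so neither compound can be ranked above the other. They also differ in more than one place, so their values do not show what any single change does.

Compound 3 (`O=C(/C=C/OC1=CC=C1)Nc1nc2ccc(Cl)cc2s1`) keeps the rest of compound 2 and changes one group: a group of 5 heavy atoms (4 carbon, 1 oxygen; one four-membered non-aromatic ring of carbon only) in place of a group of 6 heavy atoms (6 carbon; one six-membered aromatic ring of carbon only), on a double-bonded chain carbon bound to a double-bonded chain carbon. Going by the values given here, no measured pair of compounds differs in only one place, so the size of this step cannot be read directly from the data. The closest clue is that the group that enters compound 3 is already carried, on a different core, by compound 1, which gives 505 umol/kg. That number sits within the scatter of the phenyl-bearing compound 2, so no step beyond the scatter is expected, in either direction.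

The expected change is a 1.1-fold higher number from compound 2 to compound 3 (0.02 log units; within the scatter), an estimate that stays within the scatter. For compound 3 the estimated value is 450 umol/kg, with an expected range of 240 umol/kg to 850 umol/kg.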

Compound 3, dose for half-maximal effect: 544 umol/kg
Estimate against measurement, compound 3: 1.2-fold (0.08 log units) below; measured number inside the range.
By their numbers in this assay, from the lowest: compounds 2, 1 and 3 (each within the scatter of the next).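

Going by these compounds alone, the first direct reading at this position is now available: in this assay, putting the group of 5 heavy atoms with its four-membered non-aromatic carbon ring in place of phenyl gives a 1.3-fold higher number from compound 2 to compound 3 (0.11 log units; within the scatter). Within the data shown here, at this place, on a double-bonded chain carbon bound to a double-bonded chain carbon, the six-membered aromatic ring can therefore be exchanged for this non-aromatic group, which also brings one hydrogen-bond acceptor, with no step that this read-out can separate from the scatter. A second single change, chloro in place of methyl on an aromatic carbon, gives a 1.1-fold higher number from compound 1 to compound 3 (0.03 log units; within the scatter) and is equally unresolved here; no measurement offered alongside these numbers explains either result.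

From the compounds shown here alone, it remains open whether any group at this chain position can produce a step beyond the scatter, for example an amine, a carboxylic acid or a longer chain. Going by these compounds, it is also open whether a group such as fluoro or methoxy in place of the chloro or methyl on the aromatic carbon would give a step beyond the scatter.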